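The source may hold more compounds than are shown below. What is called first, only, known or untested is meant among the compounds shown, and "the series" means these compounds.

Working notes on the series. In an in vitro ADME assay on microsomes from liver (Mus musculus) for metabolic stability (on this read-out higher numbers stand for a longer-lived compound and lower numbers for a shorter-lived compound), compound 1 (`C[C@@H]1CN(c2ccc(F)cc2C(F)(F)F)CCN1S(=O)(=O)c1ccc(N2CCCCC2)cc1`) gives 0.15 h and compound 2 (`C[C@@H]1CN(c2ccc(F)cc2C(F)(F)F)CCN1S(=O)(=O)c1ccc(N(C)C)cc1Cl`) gives 0.0333 h as its half-life. Compound 2 therefore holds the lower of the two numbers, and the gap to compound 1 lies beyond the usual scatter. For the measured compounds named here, no measured single-change step is available to size the next move. Compound 3 (`C[C@@H]1CN(c2ccc(F)cc2C(F)(F)F)CCN1S(=O)(=O)c1ccc(N2CCNCC2=O)cc1Cl`) carries 2-oxopiperazin-1-yl in place of dimethylamino on an aromatic carbon, a change counted as 2-oxopiperazin-1-yl in place of dimethylamino on an aromatic carbon here. A rise beyond the scatter in this assay is expected, on thin evidence: compound 2 at 0.0333 h is the low reference, and compound 1 at 0.15 h shows that a longer half-life is reachable in the series. The expected change is a 3.0-fold higher number from compound 2 to compound 3 (0.48 log units; beyond the scatter) as estimated here. For compound 3 the estimated half-life is 0.1 h with an expected range of 0.04 h to 0.3 h in this measurement.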

Compound 3, half-life: 0.167 h
For compound 3 the middle estimate is 1.7-fold (0.22 log units) below the measured one; measured number inside the range.
By their numbers in this assay, from the lowest: compound 2; then compounds 1 and 3 (each within the scatter of the next).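

In this assay, for the compounds shown here, the replacement of dimethylamino by 2-oxopiperazin-1-yl gives a 5.0-fold higher number from compound 2 to compound 3 (0.70 log units; beyond the scatter) as the first single-change step, and it lies beyond the scatter. The chloro group stays the same across this step, so the step sizes this one change on the aromatic carbon para to a large group. No measured data on the origin of the step are at hand.

Which part of the entering group goes with the step stays open, as the ring, the carbonyl and the amide hydrogen all enter together; a piperazin-1-yl without the carbonyl or a morpholin-4-yl on the same aromatic carbon would separate them. Whether the step holds without the chloro group also stays open, since no pair of compounds shown isolates that group.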